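A few compounds are considered here, and "the series" means these few. Any claim that something is new, unique, unknown or untested is made for them only; others in the source may bear on it.

In a functional assay on U-251 cells (Homo sapiens) for inhibition, read by MTT assay, with a stated time of 2 days (on this read-out lower numbers stand for stronger inhibition of growth and higher numbers for weaker inhibition of growth), three compounds have been measured so far. Compound 1 `Nc1ccccc1NC(=O)CCCNCC(=O)Nc1ccc(Br)cc1` gives 10400 nM, compound 2 `Nc1ccccc1NC(=O)c1ccc(NCC(=O)Nc2cccc([N+](=O)[O-])c2)cc1` gives 13500 nM and compound 3 `Nc1ccccc1NC(=O)CCCNCC(=O)Nc1ccccc1Cl` gives 28600 nM. Compound 2 thus holds the middle of the three numbers: it lies within the scatter of compound 1, while its number is lower than that of compound 3 by more than the scatter.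

The unmeasured compound 4 `COc1ccc(NC(=O)CNc2ccc(C(=O)Nc3ccccc3N)cc2)cc1` keeps the core of compound 2 and alters one group: 4-methoxyphenyl in place of 3-nitrophenyl on an amide-type nitrogen. Put simply, 4-methoxyphenyl stands in place of 3-nitrophenyl on an amide-type nitrogen.

For the measured compounds named here, only one measured step bears on this change, and only loosely. On a different core, the exchange of 2-chlorophenyl for 4-bromophenyl on an amide-type nitrogen gives a 2.8-fold higher number from compound 1 to compound 3 (0.44 log units; beyond the scatter). Going by the values given here, that modest step suggests that such exchanges can move the number somewhat, but it offers no direction here, since no measured compound carries 4-methoxyphenyl. No shift beyond the scatter is therefore expected, and the estimated change is a 1.0-fold higher number from compound 2 to compound 4 (0.02 log units; within the scatter). Compound 4 is expected at about 14000 nM, with an estimated range of 6000 nM to 32000 nM.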

Compound 4, concentration for 50% growth inhibition: 25500 nM
Estimate against measurement, compound 4: 1.8-fold (0.26 log units) below; low and high end bracket the measured number.
By their numbers in this assay, from the lowest: compounds 1, 2, 4 and 3 (each within the scatter of the next, the first and the last beyond it).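

For the compounds shown here, compound 2 and compound 4 give the first measured step at this place on the core of compound 2, an amide-type nitrogen whose other neighbour is a carbonyl carbon. In this assay, 4-methoxyphenyl in place of 3-nitrophenyl gives a 1.9-fold higher number from compound 2 to compound 4 (0.28 log units; within the scatter) and so stays within the usual scatter, even though the exchange removes the nitro group, puts a methoxy group on the ring and moves the substituent to another ring position. Going by these compounds alone, the only earlier step, a 2.8-fold higher number from compound 1 to compound 3 (0.44 log units; beyond the scatter), lies beyond the scatter but belongs to a different core and to other groups, so this pair is the direct reading for this position, and no information at hand explains the result.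

The compounds shown leave open whether the nitro and methoxy groups would behave alike if each sat at the same ring position, as in 4-nitrophenyl or 3-methoxyphenyl, since this single pair changes both the group and its ring position. They also leave open how this core would respond to an unsubstituted phenyl, to the 4-bromophenyl or 2-chlorophenyl of the other core, or to a group carrying an amine or a carboxylic acid.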